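The source may report more compounds than this note shows. Statements on the series, on what has been measured and on what is new or still open speak of the compounds shown alone.

Compound 1 `COC(=O)[C@@]1(C)CCC=C2[C@@H]1CC[C@@H](C)[C@]2(C)Cc1c[nH]c2ccccc12` gives 3600 nM in a functional assay on HeLa cells (Homo sapiens) for inhibition, read by sulforhodamine B assay, with a stated time of 48 h; on this read-out lower numbers stand for stronger inhibition of growth and higher numbers for weaker inhibition of growth.
Compound 2 `COC(=O)[C@@]1(C)CCC=C2[C@@H]1CC[C@@H](C)[C@]2(C)Cc1c[nH]c2c(Cl)cccc12` gives 14000 nM.
Compound 3 `COC(=O)[C@@]1(C)CCC=C2[C@@H]1CC[C@@H](C)[C@]2(C)Cc1c(C)[nH]c2ccccc12` gives 11000 nM.

Compound 3 stands second highest of the three numbers; it lies within the usual scatter of compound 2 but is set apart from compound 1 by a 3.1-fold higher number from compound 1 to compound 3 (0.49 log units; beyond the scatter). Compound 4 `COC(=O)[C@@]1(C)CCC=C2[C@@H]1CC[C@@H](C)[C@]2(C)Cc1c(C)[nH]c2ccc(Br)cc12` differs from compound 3 by bromo in place of hydrogen on an aromatic carbon. For the measured compounds named here, two measured steps bear on this: the closest parallel is a 3.9-fold higher number from compound 1 to compound 2 (0.59 log units; beyond the scatter), and the other is a 3.1-fold higher number from compound 1 to compound 3 (0.49 log units; beyond the scatter); both additions to an aromatic carbon of the shared core gave a modest rise in this assay. A further modest rise beyond the scatter is therefore expected, written as a 2.0-fold higher number from compound 3 to compound 4 (0.30 log units; within the scatter). Compound 4 is estimated at 22000 nM, expected to fall between 8000 nM and 60000 nM.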

Compound 4, concentration for 50% growth inhibition: 11000 nM
Estimate against measurement, compound 4: 2.0-fold (0.30 log units) above; the measured number falls inside the stated range.
By their numbers in this assay, from the lowest: compound 1; then compounds 3, 4 and 2 (each within the scatter of the next).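

Placing bromo on this carbon of the six-membered aromatic ring leaves the number unchanged in this assay, with no change at the digits printed from compound 3 to compound 4 (within the scatter). The earlier steps shown here, a 3.9-fold higher number from compound 1 to compound 2 (0.59 log units; beyond the scatter) and a 3.1-fold higher number from compound 1 to compound 3 (0.49 log units; beyond the scatter), both raised the number, so compound 4 shows that adding a group to an aromatic carbon of the shared core need not weaken growth inhibition. Nothing measured here explains this difference. Going by these compounds, whether bromo would behave the same way on compound 1, which lacks the methyl group, remains open. So does the outcome of placing an amine or a carboxylic acid on this carbon.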